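The source may report more compounds than this note shows. Statements on the series, on what has been measured and on what is new or still open speak of the compounds shown alone.

Measured compounds:
compound 1 `O=C(Nc1ccc(C(F)(F)F)c(F)c1)NC1CCN(C(=O)C2(C(F)(F)F)CC2)CC1`: 5.52
compound 2 `O=C(Nc1ccc(OC(F)(F)F)cc1)NC1CCN(C(=O)C2=COCC2)CC1`: 3.49

Of the compounds shown here, two have been measured in a physicochemical assay for lipophilicity, read by HPLC, with a stated time of 90 min, tested at 100 uM; on this read-out higher numbers stand for higher lipophilicity and lower numbers for lower lipophilicity. Compound 1 gives 5.52, which is the higher of the two numbers; compound 2 gives 3.49, a gap well beyond the scatter of repeated runs. Going by the values given here, no step between two measured compounds differing in a single place is available, so the unmeasured compound 3 `O=C(Nc1ccc(C(F)(F)F)c(F)c1)NC1CCN(C(=O)[C@@H]2CCOC2)CC1` is judged from its structure alone. It differs from compound 1 in one place: oxolan-3-yl in place of 1-(trifluoromethyl)cyclopropyl on a carbonyl carbon. The group that leaves carries three fluorine atoms and the group that enters carries an oxygen instead, so in this assay the expected step from compound 1 to compound 3 is a clear fall, a number 1.62 log units lower from compound 1 to compound 3 (beyond the scatter), beyond the scatter. Compound 3 is therefore estimated at 3.9 in this assay, with a likely range from 3.3 to 4.5.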

Compound 3, partition coefficient: 3.41
For compound 3 the middle estimate is 0.49 log units above the measured one; the measured number falls inside the stated range.
By their numbers in this assay, from the lowest: compounds 3 and 2 (each within the scatter of the next); then compound 1.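

In this assay, going by these compounds alone, compounds 1 and 3 form the first pair that differs in one place, so the size of a change at this position can now be read directly. On a carbonyl carbon whose other neighbour is an amide-type nitrogen in a ring, oxolan-3-yl in place of 1-(trifluoromethyl)cyclopropyl gives a number 2.11 log units lower from compound 1 to compound 3 (beyond the scatter) and this large step shows that this group alone can move the read-out well beyond the scatter while the rest of compound 1 stays fixed. Nothing available explains the size of this step.

From the compounds shown here alone, the swap changes the ring and its substituents together, so the share of the step that belongs to the trifluoromethyl group, the cyclopropane ring or the ring oxygen stays open. A plain cyclopropyl or cyclopentyl group at this carbonyl carbon could separate these parts, and the mirror-image form of oxolan-3-yl would show whether the defined stereocentre matters here.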